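Sulfamide linker truncation within the shared core

A few compounds are considered here, and "the series" means these few. Any claim that something is new, unique, unknown or untested is made for them only; others in the source may bear on it.

Among the compounds with values here, compound 2, `NS(=O)(=O)CC(=O)NCCSc1nonc1/C(=N/O)Nc1ccc(F)c(Br)c1`, gives the lowest number of the two measured so far: in an assay for inhibition of Indoleamine 2,3-dioxygenase 1 (Homo sapiens), read by fluorescence, with a stated time of 1 h (a lower number here means a stronger inhibitor, a higher number a weaker inhibitor), compound 2 gives 71 nM, while compound 1, `COc1nonc1/C(=N/O)Nc1ccc(F)c(Br)c1`, gives 230 nM, a gap beyond the scatter. Compound 3, `NS(=O)(=O)NCCSc1nonc1/C(=N/O)Nc1ccc(F)c(Br)c1`, differs from compound 2 by sulfamoyl in place of (sulfamoylmethyl)carbonyl on an amine nitrogen. Within the data shown here, no measured pair shows this kind of change, so the step is expected to be small, at most a modest loss, with a fair chance it falls within the scatter. Compound 3 is therefore estimated at 110 nM, with a range of 35 nM to 350 nM. The expected step is a 1.5-fold higher number from compound 2 to compound 3 (0.19 log units; within the scatter).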

Compound 3, half-maximal inhibitory concentration: 130 nM
For compound 3 the middle estimate is 1.2-fold (0.07 log units) below the measured one, within the range that was stated.
By their numbers in this assay, from the lowest: compounds 2, 3 and 1 (each within the scatter of the next, the first and the last beyond it).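

In this assay, sulfamoyl in place of (sulfamoylmethyl)carbonyl on the amine nitrogen gives a step that stays within the scatter (a 1.8-fold higher number from compound 2 to compound 3 (0.26 log units; within the scatter)). On the aromatic carbon, (2-(sulfamoylamino)ethyl)sulfanyl in place of methoxy also stays within it (a 1.8-fold lower number from compound 1 to compound 3 (0.25 log units; within the scatter)), so compound 3 cannot be separated from compound 2 or compound 1, although those two stand apart. Nothing available explains these numbers.

Open, going by these compounds, is how a free amine, an acetyl group or a carboxylic acid would read at that nitrogen. On these data alone, a longer chain in place of the ethyl also remains untested here.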